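Chain extension of the hydroxamic acid linker in compound 3

The source may hold more compounds than are shown below. What is called first, only, known or untested is meant among the compounds shown, and "the series" means these compounds.

In a functional assay on CNE-2 cells (Homo sapiens) for inhibition, read by MTT assay, with a stated time of 72 h (on this read-out higher numbers stand for weaker inhibition and lower numbers for stronger inhibition), compound 3 `Nc1ncnc2c1c(-c1cnc3[nH]ccc3c1)nn2CCCCCCC(=O)NO` gives 19500 nM. Among the three measured compounds it stands second highest: compound 2 `Nc1nc2cc(-c3nn(CCCCCC(=O)NO)c4ncnc(N)c34)ccc2o1` lies nearest, at 37600 nM, a gap within the scatter, while compound 1 `CNC(=O)CCCCCCCn1nc(-c2ccc3oc(N)nc3c2)c2c(N)ncnc21` lies furthest, at 2250 nM, a gap beyond the scatter. Compound 4 `Nc1ncnc2c1c(-c1cnc3[nH]ccc3c1)nn2CCCCCCCCC(=O)NO` is not yet measured; relative to compound 3 it carries 2-(hydroxycarbamoyl)ethyl in place of hydroxycarbamoyl on a saturated chain carbon, six bonds along the chain from an aromatic nitrogen. Among the compounds with values here, the only measured step in the set is a 17-fold higher number from compound 1 to compound 2 (1.22 log units; beyond the scatter). That step alters the end group together with the chain and sits on a different core, so it bears on the present extension only loosely. Within the data shown here, no measured pair isolates a change in chain length with the hydroxycarbamoyl end kept in place. Compound 4 is therefore expected to remain close to compound 3, with the step of a 1.6-fold lower number from compound 3 to compound 4 (0.21 log units; within the scatter) expected to fall within the scatter. The estimate for compound 4 in this assay is 12000 nM, with a range from 4000 nM to 36000 nM.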

Compound 4, half-maximal inhibitory concentration: 2270 nM
The estimate for compound 4 lay 5.3-fold (0.72 log units) above the measured number; the whole stated range lies above it.
By their numbers in this assay, from the lowest: compounds 1 and 4 (each within the scatter of the next); then compounds 3 and 2 (each within the scatter of the next).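

In this assay, within the data shown here, lengthening the chain while keeping the hydroxycarbamoyl end gives an 8.6-fold lower number from compound 3 to compound 4 (0.93 log units; beyond the scatter) and is the only measured pair that isolates chain length on a shared core. The earlier step, a 17-fold higher number from compound 1 to compound 2 (1.22 log units; beyond the scatter), changes the end group together with the chain, so it could not show that 2-(hydroxycarbamoyl)ethyl in place of hydroxycarbamoyl, on a saturated chain carbon, six bonds along the chain from an aromatic nitrogen, moves the read-out beyond the scatter on its own. No available evidence bears on the origin of this step.

As far as these compounds go, a single pair defines no trend, so it remains open whether a longer chain would extend or reverse the step. Also open, from the compounds shown here alone, is how a carboxylic acid in place of the hydroxycarbamoyl end would read on the core and chain of compound 4.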